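Working notes: from compound 3 to compound 4

A few compounds are considered here, and "the series" means these few. Any claim that something is new, unique, unknown or untested is made for them only; others in the source may bear on it.

Measured so far:
compound 1, `CNC(=O)c1cc(Oc2ccc(Nc3nccc(N4CCCC4)n3)cc2)ccn1`: 59.6%
compound 2, `CCN(CC)c1ccc(C(=O)Nc2ccc(Oc3ncnc4ccsc34)cc2)cc1`: 63.8%
compound 3, `CN(c1ccc(Oc2ncnc3ccsc23)cc1)c1nccc(N2CCCC2)n1`: 63.9%

All three compounds have been run in a functional assay on A549 cells (Homo sapiens) for inhibition, read by MTT assay, with a stated time of 72 h, tested at 20 uM; a higher number here means more inhibition at the concentration tested (going by the name of the read-out), a lower number less inhibition. Compound 3 gives 63.9%, which is the highest of the three numbers, yet its gap to compound 2 and its gap to compound 1 both lie within the usual scatter of this measurement, so no ranking of the three compounds follows from these figures. For the measured compounds named here, no two measured compounds differ in only one place, so no single-change step is available from the measured set to guide the next one.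

Compound 4, `CN(c1ccc(Oc2ncnc3ccsc23)cc1)c1nccc(N2CCc3ccccc3C2)n1`, has not been measured. It differs from compound 3 in one place: 1,2,3,4-tetrahydroisoquinolin-2-yl in place of pyrrolidin-1-yl on an aromatic carbon. The entering group is the larger one and brings a second ring, as the count shows, while the donor and acceptor counts stay as they were.

Going by the values given here, with no comparable step among the measured compounds, no direction is assumed; the step is expected to be a number 3.9 percentage points lower from compound 3 to compound 4 (within the scatter), that is, no change beyond the scatter. Compound 4 is expected to give 60% in this assay, with a range from 40% to 78%.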

Compound 4, a percentage reported as inhibition, at one concentration (the size of the read-out at that concentration, not a potency): 69.9%
The estimate for compound 4 lay 9.9 percentage points below the measured number, and the stated range covers the measured number.
By their numbers in this assay, from the lowest: compounds 1, 2, 3 and 4 (each within the scatter of the next, the first and the last beyond it).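

In this assay the series now has its first step that changes one place only: 1,2,3,4-tetrahydroisoquinolin-2-yl in place of pyrrolidin-1-yl, on the aromatic carbon next to the ring nitrogen, gives a number 6 percentage points higher from compound 3 to compound 4 (within the scatter). At this position, then, the larger entering group with its second ring, carrying the same donor and acceptor counts as the group it replaces, costs nothing beyond the scatter, although the step cannot be read as a gain either. No measurement at hand bears on why the two groups read alike.

The compounds shown leave open whether this position also accepts groups of another kind, such as morpholine, a piperazine carrying a free amine, or an open-chain diethylamino group, since the two groups compared here are both ring amines without a donor. They also leave open whether the same exchange gives a similar result on the core of compound 1, and whether a potency measurement would separate compound 3 and compound 4 where a reading at one concentration does not.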